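The compounds below may be only part of what the source reports. "The series", "measured", "known", "first", "only" and "open" are said of these compounds alone.

Of the compounds shown here, three have been measured so far in a functional assay on HCT-15 cells (Homo sapiens) for cytotoxicity, read by colorimetric assay and MTT assay (a lower number here means a stronger inhibitor, a higher number a weaker inhibitor), and they show no gap: compound 1 `COc1cccc2cc(-c3ccccc3)c(O)nc12` gives 10000 nM while compound 2 `COc1ccc(-c2cc3c(OC)ccc(OC)c3nc2O)cc1` gives 10000 nM and compound 3 `CCN(CC)C(=O)Cn1c(=O)c(-c2ccc(OC)cc2)cc2c(OC)cc(OC)cc21` gives 10000 nM on the same scale. Compound 3 therefore stands level with the other two. Compound 4 `COc1ccc(-c2cc3c(OC)cc(OC)cc3n(CC(=O)OCc3ccccc3)c2=O)cc1` keeps all of compound 3 except one piece, with benzyloxy in place of diethylamino on a carbonyl carbon. For the measured compounds named here, no measured pair yet shows what a change at this place does. Going by the values given here, with compound 3 at 10000 nM as the only guide, no shift beyond the scatter is expected in this assay in either direction. The expected step of a 1.1-fold lower number from compound 3 to compound 4 (0.05 log units; within the scatter) should stay within the scatter. Compound 4 is estimated at 9000 nM with an expected range from 4000 nM to 12000 nM once it is measured.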

Compound 4, half-maximal inhibitory concentration: 10000 nM
Estimate against measurement, compound 4: 1.1-fold (0.05 log units) below, within the range that was stated.
By their numbers in this assay, from the lowest: compounds 1, 2, 3 and 4 (each within the scatter of the next).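

For the compounds shown here, putting benzyloxy in place of diethylamino on a carbonyl carbon gives, in this assay, no change at the digits printed from compound 3 to compound 4 (within the scatter), the only step read so far at this place. Exchanging diethylcarbamoyl for benzyloxycarbonyl, which adds an aromatic ring and a hydrogen-bond acceptor, therefore leaves the reading unmoved in this pair. No supporting data bear on this result. Still open, from the compounds shown here alone, is whether any group at this place can move the value in this assay. A carboxylic acid or an amine on a longer chain could answer that.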